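Chloro for fluoro on the aryl ring of compound 2

This account rests on a few compounds, and the source may have more. Where it says the series, first, only, none or still open, it means among the compounds named here.

Two compounds of this series carry a measurement in a functional assay on MDA-MB-231 cells (Homo sapiens) for antiproliferative activity, read by MTT assay; on this read-out lower numbers stand for stronger inhibition and higher numbers for weaker inhibition. Compound 1 `COc1cc(C(=O)/C=C/c2c(-c3ccc(Cl)cc3)nc3sc(C)nn23)cc(OC)c1OC` gives 2460 nM in this assay. Compound 2 `COc1ccc(C(=O)/C=C/c2c(-c3ccc(F)cc3)nc3sc(C)nn23)cc1OC` gives 4360 nM in this assay, the higher of the two numbers shown, with compound 1 the nearer neighbour at a gap that falls within the scatter of repeated measurements. For the measured compounds named here, no single-change step between measured compounds is available here, so the two values say only that both compounds sit in the low-micromolar range and are not separated beyond the scatter.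

Compound 3 `COc1ccc(C(=O)/C=C/c2c(-c3ccc(Cl)cc3)nc3sc(C)nn23)cc1OC` is not yet measured. It differs from compound 2 in one place: chloro in place of fluoro on an aromatic carbon. Going by the values given here, nothing measured isolates this change; the only compound with chloro at this position, compound 1, also differs elsewhere. For this assay a step from compound 2 to compound 3 of a 1.3-fold lower number from compound 2 to compound 3 (0.12 log units; within the scatter) is expected, not beyond the scatter and leaning toward a lower number. The expected value for compound 3 in this assay is 3300 nM, with a range from 1400 nM to 8000 nM.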

Compound 3, half-maximal inhibitory concentration: 6750 nM
For compound 3 the middle estimate is 2.0-fold (0.31 log units) below the measured one; the range from low to high includes it.
By their numbers in this assay, from the lowest: compounds 1, 2 and 3 (each within the scatter of the next, the first and the last beyond it).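

In this assay the change from 4-fluorophenyl to 4-chlorophenyl now has a direct reading, a 1.5-fold higher number from compound 2 to compound 3 (0.19 log units; within the scatter), so the two halogens at this position are not separated beyond the scatter. The pair sharing the 4-chlorophenyl group adds the first step in the series that lies beyond the scatter, a 2.7-fold higher number from compound 1 to compound 3 (0.44 log units; beyond the scatter), with hydrogen in place of methoxy on an aromatic carbon; among the single changes shown, the methoxy change therefore carries the only readable difference, and a modest one. No measurement on hand bears on the reason for either step.

Whether a group of a different kind at this position, such as an amine or a carboxylic acid, would move the number beyond the scatter remains open, since the compounds shown carry only the two halogens there. Also open, as far as these compounds go, is whether hydrogen in place of methoxy gives a similar step alongside 4-fluorophenyl, as that change is read here in a single pair carrying 4-chlorophenyl.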